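The compounds below may be only part of what the source reports. "The series", "measured", "known", "first", "only" and "open" are said of these compounds alone.

Working notes on the series. For the measured compounds named here, compound 3 `Nc1n[nH]c2cc(-c3ccc(=O)n(Cc4ccccc4F)c3)ccc12` gives 4 nM in an assay for inhibition of MAP kinase-interacting serine/threonine-protein kinase 2 (Homo sapiens), read by luminescence and ADP-Glo, with a stated time of 2 h (on this read-out lower numbers stand for stronger inhibition and higher numbers for weaker inhibition), the lowest of the three numbers so far. Compound 1 `Nc1n[nH]c2cc(-c3ccc(=O)n(Cc4cccc(Cl)c4)c3)ccc12` gives 6 nM, and the step of a 1.5-fold lower number from compound 1 to compound 3 (0.18 log units; within the scatter) lies within the scatter. Compound 2 `NC(=O)c1ccccc1Cn1cc(-c2ccc3cn[nH]c3c2)ccc1=O` gives 340 nM, far beyond the scatter from compound 3. Compound 4 `O=c1ccc(-c2ccc3cn[nH]c3c2)cn1Cc1ccccc1F` differs from compound 3 by hydrogen in place of amino on an aromatic carbon. Going by the values given here, no measured step covers this change alone; compound 2 also lacks the amino but carries a different group on the chain carbon, so its value only hints that loss of the amino costs potency. A clear rise in number is expected, a 30-fold higher number from compound 3 to compound 4 (1.48 log units; beyond the scatter), and compound 4 is estimated at 120 nM, within 25 nM to 600 nM.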

Compound 4, half-maximal inhibitory concentration: 37 nM
Compound 4: the middle estimate sits 3.2-fold (0.51 log units) above what was measured; low and high end bracket the measured number.
By their numbers in this assay, from the lowest: compounds 3 and 1 (each within the scatter of the next); then compound 4; then compound 2.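

Taken alone, hydrogen in place of amino on this aromatic carbon gives a 9.3-fold higher number from compound 3 to compound 4 (0.97 log units; beyond the scatter) and is beyond the scatter, which compound 2 could only hint at. Among compounds lacking the amino, fluoro in place of carbamoyl gives a 9.2-fold lower number from compound 2 to compound 4 (0.96 log units; beyond the scatter) and is also beyond the scatter, so that second site matters as well. No evidence at hand bears on the reason for either step.

Open, as far as these compounds go, is whether a methylamino or hydroxyl group on the same carbon would keep the lower number. Also open, from the compounds shown here alone, is how carbamoyl behaves when the amino is present.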